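The source may report more compounds than this note shows. Statements on the series, on what has been measured and on what is new or still open speak of the compounds shown alone.

Compound 3 `COc1cc2c(Oc3ccc(NC(=O)c4nn(-c5ccccc5F)c(=O)c5ccccc45)cc3F)ccnc2cc1OCCCN1CCN(C)CC1` gives 230 nM in a functional assay on NCI-H460 cells (Homo sapiens) for cytotoxicity, read by MTT assay, with a stated time of 72 h (on this read-out lower numbers stand for stronger inhibition and higher numbers for weaker inhibition), the highest of the three numbers shown. Compound 1 `COc1cc2c(Oc3ccc(NC(=O)c4nn(-c5ccc(Br)cc5)c(=O)c5ccccc45)cc3F)ccnc2cc1OCCCN1CCCC1` gives 180 nM in this assay, within the scatter of compound 3, while compound 2 `COc1cc2c(Oc3ccc(NC(=O)c4nn(-c5ccc(F)cc5)c(=O)c5ccccc45)cc3F)ccnc2cc1OCCCN1CCN(C)CC1` gives 91 nM in this assay, a lower number beyond the scatter. Compound 4 `COc1cc2c(Oc3ccc(NC(=O)c4nn(-c5ccc(Br)cc5)c(=O)c5ccccc45)cc3F)ccnc2cc1OCCCN1CCN(C)CC1` differs from compound 3 by 4-bromophenyl in place of 2-fluorophenyl on an aromatic nitrogen. For the measured compounds named here, the one measured step that bears on this is a 2.5-fold higher number from compound 2 to compound 3 (0.40 log units; beyond the scatter), which the present change largely reverses, though with bromine in place of fluorine. Compound 1 carries the same 4-bromophenyl on a different chain, and its number and that of compound 3 lie within the scatter of each other. For compound 4 a modest fall in the number is therefore expected, a 2.1-fold lower number from compound 3 to compound 4 (0.32 log units; beyond the scatter). The estimated value for compound 4 in this assay is 110 nM, with a range from 45 nM to 270 nM.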

Compound 4, half-maximal inhibitory concentration: 250 nM
Compound 4: the middle estimate sits 2.3-fold (0.36 log units) below what was measured; the range from low to high includes it.
By their numbers in this assay, from the lowest: compounds 2, 1, 3 and 4 (each within the scatter of the next, the first and the last beyond it).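

Here a 1.1-fold higher number from compound 3 to compound 4 (0.04 log units; within the scatter) in this assay means that 4-bromophenyl in place of 2-fluorophenyl brings no real gain. The halogen itself counts, as a 2.7-fold higher number from compound 2 to compound 4 (0.44 log units; beyond the scatter) goes with bromo in place of fluoro, so among these compounds the lower number of compound 2 belongs to 4-fluorophenyl alone. With 4-bromophenyl in place, a 1.4-fold higher number from compound 1 to compound 4 (0.14 log units; within the scatter) leaves 4-methylpiperazin-1-yl and pyrrolidin-1-yl on the chain indistinguishable.

As far as these compounds go, whether 4-chlorophenyl, 4-methoxyphenyl or plain phenyl would sit with compound 2 or compound 4 stays open. Nothing measured here explains the difference between fluoro and bromo.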